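Taking the Fluoro Group off Compound 3

This account rests on a few compounds, and the source may have more. Where it says the series, first, only, none or still open, it means among the compounds named here.

Compound 1 `O=[N+]([O-])c1ccc(-c2nn(-c3ccccc3)cc2C(Nc2nc3ccccc3s2)c2c(O)ccc3ccccc23)cc1`: 6810 nM
Compound 2 `COc1ccc2nc(NC(c3cn(-c4ccccc4)nc3-c3ccc(F)cc3)c3c(O)ccc4ccccc34)sc2c1`: 4630 nM
Compound 3 `Oc1ccc2ccccc2c1C(Nc1nc2ccc(Cl)cc2s1)c1cn(-c2ccccc2)nc1-c1ccc(F)cc1`: 30100 nM

These values come from a functional assay on HeLa cells (Homo sapiens) for antiproliferative activity, read by MTT assay, with a stated time of 48 h; on this read-out higher numbers stand for weaker inhibition and lower numbers for stronger inhibition. Compound 3 has the highest number of the three, which makes it the weakest inhibitor here. Compound 4 `Oc1ccc2ccccc2c1C(Nc1nc2ccc(Cl)cc2s1)c1cn(-c2ccccc2)nc1-c1ccccc1` differs from it in one place: hydrogen in place of fluoro on an aromatic carbon. In words, hydrogen stands in place of fluoro on an aromatic carbon. Within the data shown here, the only measured step is a 6.5-fold higher number from compound 2 to compound 3 (0.81 log units; beyond the scatter), for chloro in place of methoxy on an aromatic carbon. Among the measured compounds shown here, that is a different change, so it bears only weakly on this one, and no measured step removes this fluoro. A small change in this assay is therefore expected, probably within the scatter and with no firm direction. The expected step is a 1.3-fold lower number from compound 3 to compound 4 (0.10 log units; within the scatter). For compound 4 the estimate is 24000 nM, with an expected range of 9000 nM to 60000 nM.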

Compound 4, half-maximal inhibitory concentration: 12500 nM
Beside the measured number, compound 4's estimate is 1.9-fold (0.28 log units) above it, within the range that was stated.
By their numbers in this assay, from the lowest: compounds 2, 1 and 4 (each within the scatter of the next, the first and the last beyond it); then compound 3.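

In this assay, going from 4-fluorophenyl to phenyl gives a 2.4-fold lower number from compound 3 to compound 4 (0.38 log units; beyond the scatter), so the inhibition is stronger without the fluoro. Among these compounds, this is the first measured step at this position, and it shows that hydrogen serves at least as well as fluoro on this carbon while the chloro stays in place. No measurement shown here explains the change. On these data alone, it remains open whether an amine or a carboxylic acid on this carbon would lower the number further. Whether removing the fluoro has the same effect with methoxy in place of the chloro is also unknown.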